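The source may report more compounds than this note shows. Statements on the series, on what has been measured and on what is new or still open speak of the compounds shown alone.

Compound 1, `N#C[C@@H]1CCCN1C(=O)[C@@H]1CCCN1`: 2.9 nM
Compound 2, `N#C[C@@H]1CCCN1C(=O)[C@@H]1C[C@H](Nc2ccccc2)CN1`: 0.53 nM

Among the measured compounds shown here, in an assay on isolated protein for inhibition of Dipeptidyl peptidase 4 (Rattus norvegicus) (a lower number here means a stronger inhibitor, a higher number a weaker inhibitor), compound 2 gives 0.53 nM, the lowest of the two numbers known; the only other measured compound, compound 1, gives 2.9 nM. For the measured compounds named here, the single step that joins them is a 5.5-fold lower number from compound 1 to compound 2 (0.74 log units; beyond the scatter), brought about by anilino in place of hydrogen on a saturated ring carbon. Compound 3, `N#C[C@@H]1CCCN1C(=O)[C@@H]1C[C@H](Nc2ccc([N+](=O)[O-])cc2)CN1`, differs from compound 2 by nitro in place of hydrogen on an aromatic carbon. Going by the values given here, no measured step touches the aromatic ring, so the one known step offers no direct guide to this change; it only shows that the anilino group itself sits in a part of the molecule where alterations have mattered. Among the compounds with values here, with no closer precedent, the change from compound 2 to compound 3 is expected to be a 1.3-fold lower number from compound 2 to compound 3 (0.12 log units; within the scatter), within the usual scatter. Compound 3 is therefore estimated at 0.4 nM, with a range from 0.15 nM to 1.2 nM.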

Compound 3, half-maximal inhibitory concentration: 0.17 nM
For compound 3 the middle estimate is 2.4-fold (0.37 log units) above the measured one, within the range that was stated.
By their numbers in this assay, from the lowest: compound 3; then compound 2; then compound 1.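

In this assay, the aromatic ring of the anilino group proves to be a place where a further change still counts: putting nitro in place of hydrogen on an aromatic carbon, para to a large group, gives a 3.1-fold lower number from compound 2 to compound 3 (0.49 log units; beyond the scatter), a modest gain. The earlier step showed only what adding the whole anilino group does, whereas this one shows that the ring itself can carry a substituent with no loss of inhibition. No supporting data bear on why the number falls.

With a single substituent at a single place, the compounds shown cannot tell whether this gain is particular to nitro. Going by these compounds, an amine, a carboxylic acid or a methoxy group on the same carbon could give a lower number, a higher one or much the same, and other carbons of the ring remain open too.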